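Methyl on the sulfonamide ring of the benzamide series

A few compounds are considered here, and "the series" means these few. Any claim that something is new, unique, unknown or untested is made for them only; others in the source may bear on it.

Compound 1 `Cc1ccc(S(=O)(=O)NCc2ccc(CNC(=O)c3cccc(Cl)c3)cc2)cc1` and compound 2 `Cc1ccccc1C(=O)NCc1ccc(CNS(=O)(=O)c2ccccc2)cc1` have been run in an assay on MDA-MB-231 cells for binding affinity to C-X-C chemokine receptor type 4 (Homo sapiens), read by immunofluorescence and microscopy, with stated times of 10 min and 30 min; on this read-out higher numbers stand for an effect only at larger amounts of compound and lower numbers for an effect already at smaller amounts. In this assay compound 1 gives 100 nM, whereas compound 2 gives 1 nM, the lower of the two numbers, with the gap to compound 1 well beyond the scatter.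

Compound 3 `Cc1ccc(S(=O)(=O)NCc2ccc(CNC(=O)c3ccccc3C)cc2)cc1` is not yet measured; it differs from compound 2 by methyl in place of hydrogen on an aromatic carbon. Within the data shown here, no measured pair shows this change alone, so the step is expected to be small, a 2.0-fold higher number from compound 2 to compound 3 (0.30 log units; within the scatter), in the weakening direction at most slightly. For compound 3 the estimated value is 2 nM, within a range of 0.5 nM to 10 nM.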

Compound 3, effective concentration (reported as EC, without a stated level of effect): 100 nM
The estimate for compound 3 lay 50-fold (1.70 log units) below the measured number, outside the stated range (above it).
By their numbers in this assay, from the lowest: compound 2; then compounds 1 and 3 (each within the scatter of the next).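

In this assay, phenyl to 4-methylphenyl on the sulfonamide side is a large step, a 100-fold higher number from compound 2 to compound 3 (2.00 log units; beyond the scatter), so a single methyl at this position decides much of the number. With that methyl in place, 2-methylphenyl in place of 3-chlorophenyl on the carbonyl carbon gives no change at the digits printed from compound 1 to compound 3 (within the scatter), and the two amide groups are not told apart. Nothing at hand explains the loss on adding the methyl.

Open, going by these compounds, is whether a methoxy group, a fluorine or an amine at this position would behave as methyl does. Also open, on these data alone, is how 3-chlorophenyl on the carbonyl carbon reads with the plain phenyl sulfonamide.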